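Methoxy in place of methyl on compound 1

This account rests on a few compounds, and the source may have more. Where it says the series, first, only, none or still open, it means among the compounds named here.

In a functional assay on DLD-1 cells (Homo sapiens) for cytotoxicity, with a stated time of 48 h (a higher number here means a weaker inhibitor, a lower number a stronger inhibitor), compound 1 `Cc1ccc2c(=O)cc(/C=C/[S+](C)[O-])oc2c1` gives 7000 nM as its half-maximal inhibitory concentration. Compound 3 `CCCCCOc1ccc2oc(/C=C/[S+](C)[O-])cc(=O)c2c1` gives 6600 nM and so sits within the scatter of compound 1. Compound 2 `CC(=O)Oc1ccc2oc(/C=C/[S+](C)[O-])cc(=O)c2c1` gives > 10000 nM as a limit of the assay and not a number. Compound 4 `COc1ccc2c(=O)cc(/C=C/[S+](C)[O-])oc2c1` carries the change methoxy in place of methyl on an aromatic carbon with methoxy in place of methyl on an aromatic carbon. For the measured compounds named here, the one measured step of an at least 1.5-fold lower number from compound 2 to compound 3 (0.18 log units; that floor lies within the scatter) puts pentyl in place of acetyl on an oxygen on an aromatic ring. It is a different change and gives no reason to expect a move beyond the scatter in this assay for this swap. The expected step is no change at the digits printed from compound 1 to compound 4 (within the scatter) in size. Compound 4 is estimated at 7000 nM with an expected range from 3000 nM to 10000 nM once measured.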

Compound 4, half-maximal inhibitory concentration: 7800 nM
Estimate against measurement, compound 4: 1.1-fold (0.05 log units) below; low and high end bracket the measured number.
By their numbers in this assay, from the lowest: compounds 3, 1 and 4 (each within the scatter of the next). At a limit, above all of these: compound 2.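

In this assay, methoxy in place of methyl on an aromatic carbon gives a 1.1-fold higher number from compound 1 to compound 4 (0.05 log units; within the scatter), so the added oxygen, counted as one hydrogen-bond acceptor, does not separate the two compounds. For the compounds shown here, the earlier step changed a group on an oxygen, whereas this one gives the first reading of a swap on this aromatic carbon. Nothing measured here offers a cause for this result.

On these data alone, whether an amine or a carboxylic acid on this same carbon would shift the number beyond the scatter remains open.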